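The source may hold more compounds than are shown below. What is called first, only, known or untested is meant among the compounds shown, and "the series" means these compounds.

Measured compounds:
compound 1, `Cc1c(OCCCCOc2cccc(C(=O)O)c2)ccc(C(=O)CC(C)C)c1C`: "not active" (no number reported)
compound 2, `Cc1c(OCCCCOc2ccc(C(=O)O)c(Cl)c2)ccc(C(=O)CC2CCCC2)c1C`: 2420 nM
compound 3, `Cc1c(OCCCCOc2ccccc2C(=O)O)ccc(C(=O)CC(C)C)c1C`: 976 nM

In an assay on HEK293 cells for positive allosteric modulation of metabotropic glutamate receptor 2 (Rattus norvegicus), read by thallium flux, with a stated time of 2.5 min (a lower number here means that less compound is needed, a higher number that more compound is needed for the effect), compound 3 gives 976 nM, the lowest of the two numbers reported. Compound 2 gives 2420 nM, a gap beyond the scatter, and compound 1 was reported as "not active" (no number reported) with no number. Compound 4, `Cc1c(OCCCCOc2ccc(C(=O)O)c(Cl)c2)ccc(C(=O)CC(C)C)c1C`, carries the aryl group that compound 2 also carries; the change from compound 3 is 4-carboxy-3-chlorophenyl in place of 2-carboxyphenyl on an oxygen on a saturated carbon. Among the compounds with values here, no measured pair shows this change on its own. Since compound 2, which shares the entering group, gives 2420 nM, compound 4 is expected to need more compound than compound 3, with the step of a 3.1-fold higher number from compound 3 to compound 4 (0.49 log units; beyond the scatter) expected to lie beyond the scatter. Compound 4 is estimated at 3000 nM, with a range from 1000 nM to 10000 nM.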

Compound 4, half-maximal effective concentration: > 10000 nM
Compound 4: only a limit was reported; the forecaster's own chance of this, stated with the estimate: 25%; at least 3.3-fold (0.52 log units) between middle value and limit.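

Putting 4-carboxy-3-chlorophenyl in place of 2-carboxyphenyl on an oxygen on a saturated carbon costs a great deal, with an at least 10-fold higher number from compound 3 to compound 4 (1.01 log units; beyond the scatter). The other group matters as well: isopropyl in place of cyclopentyl on a saturated chain carbon bound to a carbonyl carbon gives an at least 4.1-fold higher number from compound 2 to compound 4 (0.61 log units; beyond the scatter), so with 4-carboxy-3-chlorophenyl only the cyclopentyl compound retains a number. Compound 4 has a limit rather than a number: the limit of > 10000 nM in this assay, at which 1 of the 4 values shown sits.

The compounds shown leave open how 2-carboxyphenyl behaves with cyclopentyl, and whether the chlorine or the place of the carboxylic acid accounts for the step. They also do not show whether a tetrazole could replace the carboxylic acid.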